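Replacing Phenylsulfanyl with 4-Methylpiperazin-1-yl in Compound 3

A few compounds are considered here, and "the series" means these few. Any claim that something is new, unique, unknown or untested is made for them only; others in the source may bear on it.

Of the compounds shown here, three have been tested so far in a functional assay on the whole organism with Mus musculus as the target (on this read-out lower numbers stand for an effect already at smaller amounts and higher numbers for an effect only at larger amounts of compound), and their results differ. Compound 1 (`CC1(C)Cc2cc(N)ccc2O1`) shows > 100 mg/kg as a limit of the assay and not a number. Compound 2 (`CC(C)=Cc1c(C)c(N)c(C)c2c1OC(C)(C)C2`) gives 21.9 mg/kg and compound 3 (`Cc1c(C)c2c(c(C)c1N)CC(C)(CSc1ccccc1)O2`) gives 24.7 mg/kg with these two values lying within the usual scatter of each other.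

Compound 4 (`Cc1c(C)c2c(c(C)c1N)CC(C)(CN1CCN(C)CC1)O2`) keeps the core of compound 3 but carries 4-methylpiperazin-1-yl in place of phenylsulfanyl on a saturated chain carbon bound to a saturated ring carbon. Going by the values given here, no measured pair isolates a change at a single place, so the size of this swap can only be judged indirectly. Compound 2 lacks the phenylsulfanyl group and still gives 21.9 mg/kg so a measurable effect without that group has been seen. The expected step is a 1.2-fold higher number from compound 3 to compound 4 (0.08 log units; within the scatter) which would be a small drift toward a higher number, not clearly beyond the scatter. Compound 4 is estimated at 30 mg/kg (expected range 10 mg/kg to 90 mg/kg).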

Compound 4, dose for 50% inhibition: 25.3 mg/kg
The estimate for compound 4 lay 1.2-fold (0.07 log units) above the measured number; the measured number falls inside the stated range.
By their numbers in this assay, from the lowest: compounds 2, 3 and 4 (each within the scatter of the next). At a limit, above all of these: compound 1.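

In this assay, putting 4-methylpiperazin-1-yl in place of phenylsulfanyl on a saturated chain carbon bound to a saturated ring carbon gives a 1.0-fold higher number from compound 3 to compound 4 (0.01 log units; within the scatter), and this is the only pair shown that differs in one place. It shows that this read-out does not separate a six-membered aromatic ring of carbon attached through sulfur from a six-membered non-aromatic ring with 2 hetero atoms at this position, although that holds only for these two groups. Nothing measured here explains why the two groups read alike.

As far as these compounds go, it remains open whether a much smaller group at this place, such as a hydroxyl or a primary amine, or a carboxylic acid would give a similar number. From the compounds shown here alone, it is also open whether a longer chain carrying the 4-methylpiperazin-1-yl ring would read differently.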